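The source may hold more compounds than are shown below. What is called first, only, known or untested is meant among the compounds shown, and "the series" means these compounds.

Working notes on a small set of four compounds built on two related cores. Compound 1 `CCn1nc(Cn2nnc(-c3ccccn3)n2)cc1C` and compound 3 `CCn1nc(Cn2nnnc2-c2ccccn2)cc1C` contain the same atoms joined differently; the difference between the two cores is not broken down here. In a physicochemical assay for lipophilicity (on this read-out higher numbers stand for higher lipophilicity and lower numbers for lower lipophilicity), compound 1 gives 2.08. In this assay compound 3 gives 1.34, the lowest of the three measured numbers, sitting nearest to compound 2 and furthest from compound 1. Compound 2 `Cc1cc(Cn2nnc(-c3ccccn3)n2)n[nH]1` is derived from compound 1 by hydrogen in place of ethyl on an aromatic nitrogen. In this assay compound 2 gives 1.69, so that a number 0.39 log units lower from compound 1 to compound 2 (beyond the scatter). Compound 4 `Cc1cc(Cn2nnnc2-c2ccccn2)n[nH]1` is derived from compound 3 by the same change at the same place, (hydrogen in place of ethyl on an aromatic nitrogen). This change has been measured once in the set, on the core of compound 1, and is now applied to the core of compound 3. In this assay a step of roughly the same size is expected, namely a number 0.39 log units lower from compound 3 to compound 4 (beyond the scatter), because a number 0.39 log units lower from compound 1 to compound 2 (beyond the scatter). The number for compound 4 is accordingly estimated at 0.95, with a plausible range from 0.6 to 1.3.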

Compound 4, partition coefficient: 0.86
Estimate against measurement, compound 4: 0.09 log units above; measured number inside the range.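

In this assay, hydrogen in place of ethyl on an aromatic nitrogen gives a step on each core, (a number 0.39 log units lower from compound 1 to compound 2 (beyond the scatter)) and (a number 0.48 log units lower from compound 3 to compound 4 (beyond the scatter)), so the change runs in the same direction and is modest on both, and each step lies beyond the scatter. This is one matched pair per core, which shows that the change carried over between these two cores but does not establish that it would carry over to any other core or that the two steps would recur on repeat measurement. No evidence is available on the cause of either step.

The compounds shown leave open whether the same trend would extend to other groups on that aromatic nitrogen, such as a methyl group, a longer propyl chain, or a chain ending in an amine or a carboxylic acid. They also leave open whether the step would persist if the methyl group on the same ring were replaced by, for example, a chlorine atom.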